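A few compounds are considered here, and "the series" means these few. Any claim that something is new, unique, unknown or untested is made for them only; others in the source may bear on it.

Measured in a functional assay on L1210 cells (Mus musculus) for inhibition, read by MTT assay, with a stated time of 72 h; a higher number here means a weaker inhibitor, a lower number a stronger inhibitor:

- Compound 1, `COc1cc(NC(C)CCCNC(=O)Nc2cccc(Cl)c2)c2ncccc2c1`: 17000 nM
- Compound 2, `COc1cc(NC(C)CCCNC(=O)Nc2cccc(O)c2)c2ncccc2c1`: 25000 nM
- Compound 3, `COc1cc(NC(C)CCCNC(=O)NNC(=O)Nc2cccc(F)c2)c2ncccc2c1`: 108000 nM

Of these three, compound 3 is the weakest inhibitor, at 108000 nM. The next compound to be considered is compound 4, `COc1cc(NC(C)CCCNC(=O)Nc2ccc(C(F)(F)F)cc2)c2ncccc2c1`, which has not yet been measured. It carries 4-(trifluoromethyl)phenyl in place of ((3-fluorophenyl)carbamoyl)amino on an amide-type nitrogen.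

For the measured compounds named here, two measured steps bear most directly on this change, since each joins compound 3 to a compound with a substituted phenyl on that nitrogen. They are a 6.4-fold higher number from compound 1 to compound 3 (0.80 log units; beyond the scatter) and a 4.3-fold higher number from compound 2 to compound 3 (0.64 log units; beyond the scatter). Compound 4 has the same kind of attachment, so its step should run the opposite way, towards a lower number of similar size. The remaining measured step, a 1.5-fold higher number from compound 1 to compound 2 (0.17 log units; within the scatter), suggests that exchanging one substituent on the phenyl ring need not move the value much, though only hydroxy and chloro were compared. Going by the values given here, no measured compound carries trifluoromethyl, so the range stays wide.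

The expected change is a 6.0-fold lower number from compound 3 to compound 4 (0.78 log units; beyond the scatter). For compound 4 the estimated value is 18000 nM, with an expected range of 7000 nM to 45000 nM.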

Compound 4, half-maximal inhibitory concentration: 7400 nM
Compound 4: the middle estimate sits 2.4-fold (0.39 log units) above what was measured; low and high end bracket the measured number.
By their numbers in this assay, from the lowest: compound 4; then compounds 1 and 2 (each within the scatter of the next); then compound 3.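

In this assay, putting 4-(trifluoromethyl)phenyl on the amide-type nitrogen in place of ((3-fluorophenyl)carbamoyl)amino gives a 15-fold lower number from compound 3 to compound 4 (1.16 log units; beyond the scatter) and makes compound 4 the strongest inhibitor of the four, so the group entering at this position can do better than the chloro and hydroxy compounds, not merely recover their level. The earlier comparison among substituted phenyl groups stayed within the scatter, whereas the new compound separates from both: the printed steps are a 3.4-fold lower number from compound 2 to compound 4 (0.53 log units; beyond the scatter) and a 2.3-fold lower number from compound 1 to compound 4 (0.36 log units; beyond the scatter), both modest, which shows that the choice of phenyl group at this position can itself move the number beyond the scatter. Nothing available bears on the reason for these differences.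

The compounds shown leave open whether the gain belongs to trifluoromethyl itself or to where it sits on the ring, since compound 4 differs from compound 1 and compound 2 in both the substituent and its place. They also leave open how 3-(trifluoromethyl)phenyl, an unsubstituted phenyl, or a phenyl carrying an amine or a carboxylic acid would behave on this same nitrogen.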